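The source may report more compounds than this note shows. Statements on the series, on what has been measured and on what is new or still open speak of the compounds shown alone.

Compound 1 `O=c1cc(CNCc2cccc(F)c2)oc2ccc(O)c(O)c12` is one of two measured compounds that share the same core. In an ADME assay on Huh-7 cells (Homo sapiens) for cytotoxicity (a lower number here means that less compound is tolerated, a higher number that more compound is tolerated), compound 1 gives only a limit, > 100000 nM. Compound 2 `O=c1cc(CNCc2cccc([N+](=O)[O-])c2)oc2ccc(O)c(O)c12` carries nitro in place of fluoro on an aromatic carbon. In this assay compound 2 likewise gives only a limit, > 100000 nM. The step that the two limits leave unreadable from compound 1 to compound 2 offers nothing to read, since (the limit of > 100000 nM in this assay, at which 2 of the 2 values shown sit). Compound 3 `O=c1cc(CNCc2ccc(Br)cc2)oc2ccc(O)c(O)c12` differs from compound 1 by 4-bromophenyl in place of 3-fluorophenyl on a saturated chain carbon bound to an amine nitrogen. With no readable step to lean on, the expected step that the limit leaves unreadable from compound 1 to compound 3 is none beyond the scatter. Compound 3 is therefore estimated at 150000 nM, within a range from 60000 nM to 400000 nM.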

Compound 3, half-maximal cytotoxic concentration: > 100000 nM
Compound 3 ended at the assay's limit; the forecaster's own chance of this, stated with the estimate: 80%; the middle value is on the limit's open side.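

No step can be read from compound 1 to compound 3, since both compounds stop at a limit of the assay: the limit of > 100000 nM in this assay, at which 3 of the 3 values shown sit. The compounds shown leave open whether any change on the shared core alters the result in this assay at all.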